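Naphthyl thiosemicarbazones: halogen pattern on the benzylidene ring

The source may hold more compounds than are shown below. What is called first, only, known or untested is meant among the compounds shown, and "the series" means these compounds.

For the measured compounds named here, compound 3 `Fc1ccc(/C=N/NC(=S)Nc2cccc3ccccc23)cc1F` gives 125 ug/mL in a functional assay on A549 cells (Homo sapiens) for cytotoxicity, read by XTT assay, with a stated time of 24 h (a lower number here means a stronger inhibitor, a higher number a weaker inhibitor), the second highest of the three numbers so far: compound 2 `Fc1ccc(/C=N/NC(=S)Nc2cccc3ccccc23)c(F)c1` gives 31.3 ug/mL and compound 1 `Fc1cccc(/C=N/NC(=S)Nc2cccc3ccccc23)c1F` gives 500 ug/mL. Compound 4 `Fc1cccc(Cl)c1/C=N/NC(=S)Nc1cccc2ccccc12` carries 2-chloro-6-fluorophenyl in place of 3,4-difluorophenyl on a carbon with a double bond to nitrogen. Going by the values given here, no measured step introduces chlorine on this ring; the steps that bear on the change move only fluorine, namely a 4.0-fold lower number from compound 1 to compound 3 (0.60 log units; beyond the scatter) and a 4.0-fold higher number from compound 2 to compound 3 (0.60 log units; beyond the scatter), while a 16-fold lower number from compound 1 to compound 2 (1.20 log units; beyond the scatter) shows the widest swing. Rearranging the halogens has therefore shifted this assay by modest to large amounts in both directions, so a step of comparable size is expected here with its direction uncertain, and no change at the digits printed from compound 3 to compound 4 (within the scatter) is set at the centre of that spread. Compound 4 is estimated at 125 ug/mL, with a range from 31 ug/mL to 500 ug/mL.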

Compound 4, half-maximal inhibitory concentration: 125 ug/mL
Compound 4: the middle estimate sits on the measured number at the digits printed; measured number inside the range.
By their numbers in this assay, from the lowest: compound 2; then compounds 3 and 4 (each within the scatter of the next); then compound 1.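

In this assay, chlorine on this ring gives no change at the digits printed from compound 3 to compound 4 (within the scatter), so 2-chloro-6-fluorophenyl and 3,4-difluorophenyl cannot be told apart here. The chlorine-bearing ring still separates from the other two fluorine patterns, with a 4.0-fold higher number from compound 2 to compound 4 (0.60 log units; beyond the scatter) and a 4.0-fold lower number from compound 1 to compound 4 (0.60 log units; beyond the scatter), leaving compounds 3 and 4 in the middle of the series. No measurement available bears on why these halogen patterns differ. Open, from the compounds shown here alone, is whether bromine, methoxy or an amine on this ring would stay inside the span from compound 2 to compound 1. Also open, going by these compounds, is how chlorine alone acts, as compound 4 differs from each other compound in both halogen identity and pattern.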